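The compounds below may be only part of what the source reports. "The series", "measured", "known", "first", "only" and "open" are said of these compounds alone.

Measured compounds in a functional assay on MDA-MB-231 cells (Homo sapiens) for cytotoxicity, read by MTT assay, with a stated time of 72 h; on this read-out higher numbers stand for weaker inhibition and lower numbers for stronger inhibition:
Compound 1 `CCCCCCNc1nc(SCc2ccc(C(F)(F)F)cc2)nc2ccccc12`: 20200 nM
Compound 2 `FC(F)(F)c1ccc(CSc2nc(Nc3ccccc3C(F)(F)F)c3ccccc3n2)cc1`: > 50000 nM, a limit of the assay rather than a number
Compound 3 `COc1ccccc1Nc1nc(SCc2ccc(C(F)(F)F)cc2)nc2ccccc12`: > 50000 nM, a limit of the assay rather than a number

Within the data shown here, compound 1 is the only member of the set with an actual number in this assay; the other two results sit at a limit. The unmeasured compound 4 `Cc1ccccc1Nc1nc(SCc2ccc(C(F)(F)F)cc2)nc2ccccc12` differs from compound 1 by 2-methylphenyl in place of hexyl on a nitrogen on an aromatic ring. Among the measured compounds shown here, two measured steps bear on this change, each swapping the same hexyl for a phenyl carrying a single group: an at least 2.4-fold higher number from compound 1 to compound 2 (0.39 log units; beyond the scatter) and an at least 2.4-fold higher number from compound 1 to compound 3 (0.39 log units; beyond the scatter). From the compounds shown here alone, both run in the direction of weaker inhibition, both beyond the scatter, and both end at the limit of > 50000 nM in this assay, at which 2 of the 3 values shown sit, so their true size is unknown. The comparison between the two aryl analogues, a step that the two limits leave unreadable from compound 2 to compound 3, gives no further reading. On this basis the step to compound 4 is expected to be at least modest and in the same direction, with a fair chance that the assay again reports only a limit. Compound 4 is therefore estimated at 55000 nM in this assay, within a range of 20000 nM to 150000 nM, resting on the steps to compound 2 an at least 2.4-fold higher number from compound 1 to compound 2 (0.39 log units; beyond the scatter) and compound 3 an at least 2.4-fold higher number from compound 1 to compound 3 (0.39 log units; beyond the scatter). The expected step is a 2.7-fold higher number from compound 1 to compound 4 (0.44 log units; beyond the scatter).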

Compound 4, half-maximal inhibitory concentration: 27100 nM
Beside the measured number, compound 4's estimate is 2.0-fold (0.31 log units) above it, within the range that was stated.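

In this assay, a phenyl ring on the nitrogen does not by itself separate an analogue from the hexyl compound: 2-methylphenyl in place of hexyl gives a 1.3-fold higher number from compound 1 to compound 4 (0.13 log units; within the scatter) and so shows no readable change at this position, something the earlier aryl compounds could not show. Among the aryl analogues, methyl in place of methoxy gives an at least 1.8-fold lower number from compound 3 to compound 4 (0.26 log units; that floor lies within the scatter) and methyl in place of trifluoromethyl gives an at least 1.8-fold lower number from compound 2 to compound 4 (0.26 log units; that floor lies within the scatter) so the group on the phenyl ring may matter, though neither floor goes beyond the scatter. These two steps remain floors, and the step between compound 2 and compound 3 cannot be read, because both of those compounds sit at a limit of the assay: the limit of > 50000 nM in this assay, at which 2 of the 4 values shown sit.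

From the compounds shown here alone, how far compound 2 and compound 3 truly lie from compound 4 remains open, which leaves the order of methyl, methoxy and trifluoromethyl on the phenyl ring unsettled. Also open, going by these compounds, is whether unsubstituted phenyl, cyclohexyl or a shorter chain such as butyl on the same nitrogen would read alongside compound 1 and compound 4 in this assay or move beyond the scatter.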